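The source may hold more compounds than are shown below. What is called first, only, known or untested is meant among the compounds shown, and "the series" means these compounds.

Measured compounds in the series:

- compound 1 `O=S(=O)(NCCCNCc1ccc(Cl)c(Cl)c1)c1cc(C(F)(F)F)cc(C(F)(F)F)c1` — 2700 nM
- compound 2 `COc1ccc(CNCCCNS(=O)(=O)c2cc(C(F)(F)F)cc(C(F)(F)F)c2)cc1OC` — 2800 nM
- compound 3 `O=S(=O)(NCCCNCc1ccccc1)c1cc(C(F)(F)F)cc(C(F)(F)F)c1` — 11000 nM

All three share one core and differ only in the aryl group on the saturated chain carbon bound to an amine nitrogen. In a functional assay on MIA PaCa-2 cells (Homo sapiens) for inhibition, read by MTT assay, with a stated time of 72 h (a lower number here means a stronger inhibitor of growth, a higher number a weaker inhibitor of growth), compound 3 stands with the highest number of the three: the steps of a 4.1-fold higher number from compound 1 to compound 3 (0.61 log units; beyond the scatter) and a 3.9-fold higher number from compound 2 to compound 3 (0.59 log units; beyond the scatter) both lie beyond the scatter, whereas a 1.0-fold higher number from compound 1 to compound 2 (0.02 log units; within the scatter) lies within it, so compound 1 and compound 2 cannot be ordered against each other.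

Compound 4 `O=S(=O)(NCCCNCc1ccc(Br)cc1)c1cc(C(F)(F)F)cc(C(F)(F)F)c1` has not yet been measured. It differs from compound 3 by bromo in place of hydrogen on an aromatic carbon, the bromo sitting on an aromatic carbon of a six-membered aromatic ring of carbon only, para to a large group. The two steps that bear on it are those from the substituted rings of compound 1 and compound 2 to the bare phenyl of compound 3; each of them raised the number by a modest amount of closely similar size. A single bromo is a smaller change than either of the substituted rings seen so far, so a step down of similar or somewhat smaller size in this assay is expected, a 2.8-fold lower number from compound 3 to compound 4 (0.44 log units; beyond the scatter). Compound 4 is therefore estimated at 4000 nM, with a range from 2000 nM to 9000 nM.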

Compound 4, concentration for 50% growth inhibition: 2300 nM
Estimate against measurement, compound 4: 1.7-fold (0.24 log units) above; the measured number falls inside the stated range.
By their numbers in this assay, from the lowest: compounds 4, 1 and 2 (each within the scatter of the next); then compound 3.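

In this assay, bromo in place of hydrogen, para to a large group, gives a 4.8-fold lower number from compound 3 to compound 4 (0.68 log units; beyond the scatter), a change of the same modest size as those separating compound 3 from compound 1 and compound 2, and here it comes from a single heavy atom on the ring. Compound 4 cannot be ordered against the two earlier substituted compounds, as a 1.2-fold lower number from compound 2 to compound 4 (0.09 log units; within the scatter) and a 1.2-fold lower number from compound 1 to compound 4 (0.07 log units; within the scatter) both lie within the scatter, so 4-bromophenyl, 3,4-dichlorophenyl and 3,4-dimethoxyphenyl stand together, with only the bare phenyl of compound 3 set apart from them. Nothing available explains why these substituted rings differ from the bare phenyl.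

Going by these compounds, whether this step is particular to bromo remains open, and a 4-fluorophenyl, 4-methoxyphenyl or 4-carboxyphenyl group at the same place would test it. On these data alone, the rest of the shared core stays constant across all four compounds, so it is also open whether these steps would hold with a longer chain or with an amide in place of the amine.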